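Trimming the Aryl Methyl on a Piperazine Sulfonamide

The compounds below may be only part of what the source reports. "The series", "measured", "known", "first", "only" and "open" are said of these compounds alone.

Measured so far:
Compound 1, `CCCn1c(=O)[nH]c2nc(-c3ccc(S(=O)(=O)N4CCN(c5ccccc5C)CC4)cc3)[nH]c2c1=O`: 25%
Compound 2, `CCCn1c(=O)[nH]c2nc(-c3ccc(S(=O)(=O)N4CCN(C)CC4)cc3)[nH]c2c1=O`: 7%
Compound 3, `CCCn1c(=O)[nH]c2nc(-c3ccc(S(=O)(=O)N4CCN(c5ccc(C)cc5)CC4)cc3)[nH]c2c1=O`: 25%

In an assay on CHO cells for displacement of a labelled ligand from adenosine receptor A3 (Homo sapiens), read by scintillation counting, with a stated time of 45 min, tested at 1 uM, in the presence of a further agent that is not named here (on this read-out higher numbers stand for more inhibition at the one concentration tested (going by the name of the read-out) and lower numbers for less inhibition), compound 3 gives 25%, level with compound 1 at the digits printed, together the highest of the three numbers, while compound 2 gives 7%. Compound 4 is `CCCn1c(=O)[nH]c2nc(-c3ccc(S(=O)(=O)N4CCN(c5ccccc5)CC4)cc3)[nH]c2c1=O`; its difference from compound 3 is hydrogen in place of methyl on an aromatic carbon. For the measured compounds named here, two measured steps bear on this. Moving the methyl around the ring gave no change at the digits printed from compound 1 to compound 3 (within the scatter), whereas replacing the aryl group by methyl gave a number 18 percentage points higher from compound 2 to compound 3 (beyond the scatter). Compound 4 keeps the aryl group and loses only the methyl, so a step of a number 3 percentage points lower from compound 3 to compound 4 (within the scatter) is expected, within the scatter. Compound 4 is estimated at 22%, between 8% and 36%.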

Compound 4, a percentage reported as inhibition, at one concentration (the size of the read-out at that concentration, not a potency): 27%
Compound 4: the middle estimate sits 5 percentage points below what was measured, and the stated range covers the measured number.
By their numbers in this assay, from the lowest: compound 2; then compounds 1, 3 and 4 (each within the scatter of the next).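

Taking the methyl off the ring gives a number 2 percentage points higher from compound 3 to compound 4 (within the scatter) and likewise a number 2 percentage points higher from compound 1 to compound 4 (within the scatter) and so the plain phenyl stands level with both methylphenyl compounds, which shows that this methyl is not needed to hold the inhibition seen here. Phenyl in place of methyl on the amine nitrogen gives a number 20 percentage points higher from compound 2 to compound 4 (beyond the scatter) and so the gain seen with the methylphenyl groups also appears with the bare aryl ring. Nothing measured here gives a reason for these results. Open, from the compounds shown here alone, is whether a chlorine atom, a methoxy group or a carboxylic acid on this phenyl would move the number. Also open, going by these compounds, is whether a benzyl group on the nitrogen would match phenyl.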